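From a pyrrolidine sulfonamide to an anilide

The source may hold more compounds than are shown below. What is called first, only, known or untested is meant among the compounds shown, and "the series" means these compounds.

Compound 2, `O=S(=O)(c1ccc(F)c2ncc(I)cc12)N1CCCC1`, belongs to a small series built on a shared core, alongside compound 1, `CNS(=O)(=O)c1ccc(F)c2ncc(I)cc12`. In an assay for inhibition of methylcytosine dioxygenase TET2 (Homo sapiens), read by mass spectrometry, with stated times of 30 min and 1 h (a lower number here means a stronger inhibitor, a higher number a weaker inhibitor), compound 1 gives only a limit of > 200000 nM. In this assay compound 2 likewise gives only a limit, > 200000 nM. Among the compounds with values here, the one measured step, a step that the two limits leave unreadable from compound 1 to compound 2, therefore cannot be sized, and the sole evidence in hand is the limit of > 200000 nM in this assay, at which 2 of the 2 values shown sit.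

Compound 3, `O=S(=O)(Nc1ccccc1)c1ccc(F)c2ncc(I)cc12`, differs from compound 2 by anilino in place of pyrrolidin-1-yl on a sulfonyl sulfur. Within the data shown here, no measured step mirrors that exchange, and the single step available bears on it only in that both of its ends sit at the limit. Nothing among the numbers shown supports an expectation of a step beyond the scatter in either direction in this assay. Compound 3 is therefore expected at about 300000 nM, within 80000 nM to 1000000 nM, with a fair chance that only a limit is reported again. That estimate corresponds to a step that the limit leaves unreadable from compound 2 to compound 3, expected to stay within the scatter.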

Compound 3, half-maximal inhibitory concentration: 23900 nM
Estimate against measurement, compound 3: 13-fold (1.10 log units) above, and the stated range ends above it.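

In this assay, within the data shown here, compound 3 gives the only number of the three that is not a limit, so this position on the sulfonyl sulfur can now be seen to affect the read-out. Anilino in place of pyrrolidin-1-yl brings an at least 8.3-fold lower number from compound 2 to compound 3 (0.92 log units; beyond the scatter), and phenyl in place of methyl on the sulfonamide nitrogen brings an at least 8.3-fold lower number from compound 1 to compound 3 (0.92 log units; beyond the scatter). Compound 1 also keeps a hydrogen on that nitrogen, so the hydrogen alone does not give a readable number, and the two other values remain limits: the limit of > 200000 nM in this assay, at which 2 of the 3 values shown sit.

The compounds shown leave open how large either step truly is, and whether a cyclohexyl or benzyl group on that nitrogen would serve as the phenyl ring does. They also leave open how a chlorine, an amine or a carboxylic acid on the phenyl ring would read.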